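This account rests on a few compounds, and the source may have more. Where it says the series, first, only, none or still open, it means among the compounds named here.

Compound 3 `Cc1cc(-c2ccoc2)c2ncc(CSCCc3ccccc3)n2c1` gives 64 ug/mL in an ADME assay on HEL cells (Homo sapiens) for cytotoxicity, with a stated time of 3 days (a lower number here means that less compound is tolerated, a higher number that more compound is tolerated), the highest of the three numbers measured; compound 2 `Cc1cc(Sc2ccc(Cl)cc2)cn2c(CSCCc3ccccc3)cnc12` gives 14 ug/mL and compound 1 `Cc1cc(-c2ccoc2)cn2c(CSCCc3ccccc3)cnc12` gives 12 ug/mL, both lower by more than the usual scatter. Compound 4 `Cc1cc(-n2ccc3cccnc32)c2ncc(CSCCc3ccccc3)n2c1` differs from compound 3 by a group of 9 heavy atoms (7 carbon, 2 nitrogen; one five-membered aromatic ring with 1 hetero atom, one six-membered aromatic ring with 1 hetero atom) in place of a group of 5 heavy atoms (4 carbon, 1 oxygen; one five-membered aromatic ring with 1 hetero atom), on an aromatic carbon. Going by the values given here, the only measured step that bears on it, the exchange of the aromatic group on the shared core a 1.2-fold higher number from compound 1 to compound 2 (0.07 log units; within the scatter), stayed within the scatter, so a step of similar size, in no clear direction, is expected in this assay from compound 3 to compound 4 a 1.3-fold lower number from compound 3 to compound 4 (0.11 log units; within the scatter). Compound 4 is therefore estimated at 50 ug/mL, with a range from 20 ug/mL to 100 ug/mL.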

Compound 4, half-maximal cytotoxic concentration: > 100 ug/mL
Compound 4 was reported as a limit; the forecaster's own chance of this, stated with the estimate: 10%; at least 2.0-fold (0.30 log units) between middle value and limit.
By their numbers in this assay, from the lowest: compounds 1 and 2 (each within the scatter of the next); then compound 3. At a limit, above all of these: compound 4.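

In this assay, the two-ring group in place of furan-3-yl on this aromatic carbon, ortho to a fused ring, brings no drop in the number (an at least 1.5-fold higher number from compound 3 to compound 4 (0.19 log units; that floor lies within the scatter)). This is the first exchange shown at this position, and the larger group is tolerated at least as well as furan-3-yl. Compound 4 is reported only as a limit, so the full size of the step cannot be read: the limit of > 100 ug/mL in this assay, at which 1 of the 4 values shown sits.

Open, as far as these compounds go, is how a smaller group, such as an amine or a carboxylic acid, would fare on this carbon. Also open, from the compounds shown here alone, is whether a plain phenyl ring would give a similar number.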